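A few compounds are considered here, and "the series" means these few. Any claim that something is new, unique, unknown or untested is made for them only; others in the source may bear on it.

Of the compounds shown here, two with a shared core have been measured so far. In a functional assay on HepG2 cells (Homo sapiens) for cytotoxicity, read by MTT assay, with a stated time of 48 h (a lower number here means a stronger inhibitor, a higher number a weaker inhibitor), compound 1 (`Cc1ccc(/C=C2/S/C(=N/c3ccccc3)N(Cc3ccncc3)C2=O)cc1`) gives 19700 nM and compound 2 (`COc1ccc(OC)c(/C=C2/S/C(=N/c3ccccc3)N(Cc3ccncc3)C2=O)c1`) gives 35800 nM as its value. Compound 2 therefore stands level with compound 1 within the usual scatter of repeated measurements, and there is no third number to place it against.

Among the compounds with values here, compound 3 (`O=C1/C(=C\c2cccc(O)c2)S/C(=N/c2ccccc2)N1Cc1ccncc1`) keeps the core and carries 3-hydroxyphenyl in place of 2,5-dimethoxyphenyl on a double-bonded chain carbon bound to a double-bonded ring carbon as its only change. Within the data shown here, one measured step bears on this, at the same place: a 1.8-fold higher number from compound 1 to compound 2 (0.26 log units; within the scatter) as the swap of 4-methylphenyl for 2,5-dimethoxyphenyl. Going by these compounds, that is a small step, but neither measured compound carries a hydroxyl group, so the new group remains untested and the range must stay wide.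

In this assay no step beyond the scatter is therefore expected, and the estimated change is a 1.4-fold lower number from compound 2 to compound 3 (0.16 log units; within the scatter) in size. For compound 3 the estimated value is 25000 nM with an expected range from 10000 nM to 60000 nM for repeated measurements.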

Compound 3, half-maximal inhibitory concentration: 17600 nM
For compound 3 the middle estimate is 1.4-fold (0.15 log units) above the measured one; measured number inside the range.
By their numbers in this assay, from the lowest: compounds 3, 1 and 2 (each within the scatter of the next, the first and the last beyond it).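

At this place, on a double-bonded chain carbon bound to a double-bonded ring carbon, this assay now shows its first step beyond the scatter, a 2.0-fold lower number from compound 2 to compound 3 (0.31 log units; beyond the scatter), though it is only a modest one. The hydroxyl group does not separate compound 3 from the 4-methylphenyl compound, as a 1.1-fold lower number from compound 1 to compound 3 (0.05 log units; within the scatter) stays within the scatter, so a hydroxyl group at this place is tolerated but brings no clear gain over that group. The swap from 2,5-dimethoxyphenyl to 3-hydroxyphenyl changes several things at once, going from 10 heavy atoms to 7 and from 0 hydrogen-bond donors to 1, and no available evidence ties the step to any one of these changes.

The compounds shown leave open whether the step goes with gaining the hydroxyl group or with losing the two methoxy groups, a question that an unsubstituted phenyl or a 3-methoxyphenyl at this place could help to separate. They also leave open how an amine or a carboxylic acid on this phenyl ring would read in this assay.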